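Butylamino against methylamino on two related quinone cores

A few compounds are considered here, and "the series" means these few. Any claim that something is new, unique, unknown or untested is made for them only; others in the source may bear on it.

Compound 2 `CNC1=CC(=O)C=C(C(C)(C)C)C1=O` and compound 1 `CCCCNC1=CC(=O)C=C(C(C)(C)C)C1=O` share one core. In a functional assay on NCI-H460 cells (Homo sapiens) for cytotoxicity, read by MTT assay, with a stated time of 72 h (on this read-out higher numbers stand for weaker inhibition and lower numbers for stronger inhibition), compound 2 gives 25000 nM, and compound 1 gives 14000 nM. The change between them is propyl in place of hydrogen on a saturated chain carbon bound to an amine nitrogen, and it made a step of a 1.8-fold lower number from compound 2 to compound 1 (0.25 log units; within the scatter). Compound 3 `CNC1=CC(=O)C(C(C)(C)C)=CC1=O` has the same atoms as compound 2 joined differently; the difference between the two cores is not broken down here. In this assay compound 3 gives 63000 nM, the highest of the three numbers, beyond the scatter from both of the others. Compound 4 `CCCCNC1=CC(=O)C(C(C)(C)C)=CC1=O` is not yet measured. It differs from compound 3 by propyl in place of hydrogen on a saturated chain carbon bound to an amine nitrogen, the same change that separates compound 2 from compound 1, at the same place. On the core of compound 2 that change stayed within the scatter, so on the core of compound 3 a step of about the same size is expected, a 1.8-fold lower number from compound 3 to compound 4 (0.26 log units; within the scatter), resting on a 1.8-fold lower number from compound 2 to compound 1 (0.25 log units; within the scatter). Whether the core of compound 3 answers the change as the core of compound 2 did is not known, so the range is kept wide. The estimate for compound 4 in this assay is 35000 nM, between 15000 nM and 90000 nM.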

Compound 4, half-maximal inhibitory concentration: 36000 nM
The estimate for compound 4 lay 1.0-fold (0.01 log units) below the measured number, and the stated range covers the measured number.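

In this assay, replacing methylamino with butylamino on the core of compound 3 gives a 1.8-fold lower number from compound 3 to compound 4 (0.24 log units; within the scatter). Set beside the earlier step on the core of compound 2, the change carries from one core to the other with no visible difference in size: the same change on two cores in this assay, a 1.8-fold lower number (0.25 log units; within the scatter) from compound 2 to compound 1 and a 1.8-fold lower number (0.24 log units; within the scatter) from compound 3 to compound 4, 1.0-fold (0.01 log units) apart, within the scatter of two such steps. This agreement does not show that the longer chain gives a real gain, as each step on its own stays within the scatter, and two cores give no basis for a rule covering other cores in the series, nor do they explain why the steps match.

The compounds shown cover only methylamino and butylamino, so it remains open how a longer chain such as octylamino, a chain ending in a hydroxyl or a carboxylic acid, or a ring amine such as morpholine would behave on either core. Also open, as far as these compounds go, is whether the match between the two steps would hold in other cells.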